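Cyclohexylamide to Pyrrolidine Amide on a Shared Core

This account rests on a few compounds, and the source may have more. Where it says the series, first, only, none or still open, it means among the compounds named here.

Of the compounds shown here, three built on one shared core have been measured. Compound 1 `COc1cc2c(cc1OC)C(CC(=O)O)CC2` carries a carboxylic acid; in a functional assay on the whole organism (strain Wistar) for inhibition, with Rattus norvegicus as the target, read by paw edema, with stated times of 60 min and 6 h, at a dose of 100 mg/kg by the oral route (a lower number here means less inhibition, a higher number more inhibition at the dose given (going by the name of the read-out)), compound 1 gives 20.4%. Compound 2 `COc1cc2c(cc1OC)C(CC(N)=O)CC2` carries the plain amide, and in this assay compound 2 gives 27.8%. Compound 3 `COc1cc2c(cc1OC)C(CC(=O)NC1CCCCC1)CC2` carries a cyclohexyl group on the amide nitrogen, and in this assay compound 3 gives 48.2%, the highest of the three numbers, with both other compounds beyond the scatter below it.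

For the measured compounds named here, two measured steps bear on the next change: a number 27.8 percentage points higher from compound 1 to compound 3 (beyond the scatter) and a number 20.4 percentage points higher from compound 2 to compound 3 (beyond the scatter). The smaller step of a number 7.4 percentage points higher from compound 1 to compound 2 (within the scatter) stayed within the scatter, so the gain came with the cyclohexyl group rather than with the amide itself.

Compound 4 `COc1cc2c(cc1OC)C(CC(=O)N1CCCC1)CC2` differs from compound 3 in one place: pyrrolidin-1-yl in place of cyclohexylamino on a carbonyl carbon. The nitrogen keeps a ring but loses its hydrogen, and the ring is now smaller and contains the nitrogen. Going by the values given here, no measured step matches this exact change. A step downward of modest size is expected in this assay, because a number 20.4 percentage points higher from compound 2 to compound 3 (beyond the scatter) shows how much the cyclohexyl group contributed and part of that is now removed. The expected step is a number 10.2 percentage points lower from compound 3 to compound 4 (beyond the scatter). Compound 4 is estimated to give 38%, within a range from 22% to 52%.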

Compound 4, a percentage reported as inhibition, in the whole organism at one dose (the size of the read-out at that dose, not a potency): 22.2%
The estimate for compound 4 lay 15.8 percentage points above the measured number; the range from low to high includes it.
By their numbers in this assay, from the lowest: compounds 1, 4 and 2 (each within the scatter of the next); then compound 3.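

In this assay, the step of a number 26 percentage points lower from compound 3 to compound 4 (beyond the scatter) shows that the higher number at this position does not come from simply having a ring on the amide nitrogen, since the pyrrolidin-1-yl group of compound 4 carries a ring too and the gain over the simpler compounds is not kept. Compound 4 instead stands level with the plain amide and the carboxylic acid, as the step of a number 5.6 percentage points lower from compound 2 to compound 4 (within the scatter) and the step of a number 1.8 percentage points higher from compound 1 to compound 4 (within the scatter) show, so on this carbonyl carbon the pyrrolidin-1-yl group offers no measurable advantage over the amino or hydroxy group, while the cyclohexylamino group does. Nothing available explains why the number falls with this change.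

The change alters two things at once, the amide hydrogen and the ring, and these compounds cannot say which of them matters, or whether both do. A cyclopentylamino group, which keeps the amide hydrogen on a smaller ring, and a piperidin-1-yl group, which lacks that hydrogen but has a six-membered ring, would pull the two apart on the same carbonyl carbon.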